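The source may report more compounds than this note shows. Statements on the series, on what has been measured and on what is new or still open speak of the compounds shown alone.

Measured compounds
- compound 1, `C/C=C(\C)C(=O)O[C@@H]1C(=O)/C=C2/C3=CC(=O)O[C@@H](c4ccoc4)[C@]3(C)CC[C@@H]2[C@@]2(C)C(=O)C[C@]1(C)[C@@H]2[C@@H](O)C(=O)OC`: 10500 nM in a functional assay on DU-145 cells (Homo sapiens) for inhibition, read by MTT assay, with a stated time of 24 h; a lower number here means a stronger inhibitor, a higher number a weaker inhibitor
- compound 2, `C/C=C(\C)C(=O)O[C@H]1[C@]2(C)C[C@@H]3O[C@@]1(O)C=C1C4=CC(=O)O[C@@H](c5ccoc5)[C@]4(C)CC[C@@H]1[C@]3(C)[C@@H]2[C@@H](O)C(=O)OC`: 7700 nM
- compound 3, `COC(=O)[C@H](O)[C@@H]1[C@@]2(C)C[C@@H]3O[C@@](O)(C=C4C5=CC(=O)O[C@@H](c6ccoc6)[C@]5(C)CC[C@@H]4[C@@]31C)[C@H]2O`: > 100000 nM, a limit of the assay and not a number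

Compound 2 gives the lowest of the two numbers; compound 1 is its nearest neighbour, within the usual scatter, so no order between compound 1 and compound 2 is claimed. For compound 3 only a limit is reported, (the limit of > 100000 nM in this assay, at which 1 of the 3 values shown sits).

Among the compounds with values here, the one step that differs in a single place is an at least 12-fold higher number from compound 2 to compound 3 (1.11 log units; beyond the scatter); it removes the ester on an oxygen on a saturated carbon, and its size is bounded only by the limit (the limit of > 100000 nM in this assay, at which 1 of the 3 values shown sits).

Compound 4, `C/C=C(\C)C(=O)O[C@H]1[C@]2(C)C[C@@H]3O[C@@]1(O)C=C1C4=CC(=O)O[C@@H](c5ccoc5)[C@]4(C)CC[C@@H]1[C@]3(C)[C@@H]2C(=O)C(=O)OC`, differs from compound 2 by (methoxycarbonyl)carbonyl in place of hydroxy(methoxycarbonyl)methyl on a saturated ring carbon. This change leaves the ester of compound 2 in place and touches neither the position nor the kind of group altered between compound 2 and compound 3, so the measured step gives no direct guidance on it. With no evidence that this position matters, the expectation in this assay is a step of no more than the scatter, a 1.0-fold higher number from compound 2 to compound 4 (0.02 log units; within the scatter), in either direction. Compound 4 is therefore estimated at 8000 nM, with a range from 3000 nM to 25000 nM.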

Compound 4, half-maximal inhibitory concentration: > 100000 nM
Compound 4 gave a limit, no number; the forecaster's own chance of this, stated with the estimate: 10%; middle value at least 12-fold (1.09 log units) from the limit.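

In this assay, the carbon chain on the saturated ring carbon proves to be a sensitive site: the exchange of hydroxy(methoxycarbonyl)methyl for (methoxycarbonyl)carbonyl gives an at least 12-fold higher number from compound 2 to compound 4 (1.11 log units; beyond the scatter), with the (1-methylprop-1-en-1-yl)carbonyl ester left in place. Retaining that ester is therefore not enough to keep a measurable number in this series, and the earlier compounds, whose only single-place step concerned the ester, could not show this. The groups that leave and enter match in heavy atoms, and the change removes the hydrogen-bond donor and the defined stereocentre and adds a double bond; compound 4 gives a limit and not a number, so the size of the step is bounded only by that limit: the limit of > 100000 nM in this assay, at which 2 of the 4 values shown sit.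

The compounds shown do not separate the loss of the hydroxy hydrogen from the loss of the defined stereocentre or the gain of the carbonyl, and a methoxy group or an amine on that chain carbon would bear on this. Also open, on these data alone, is whether the methyl ester matters here, a question that a carboxylic acid in its place would address.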